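A few compounds are considered here, and "the series" means these few. Any claim that something is new, unique, unknown or untested is made for them only; others in the source may bear on it.

Compound 1 `C=C(Br)C(=O)Nc1cccc(-c2cn3nc(Cc4cccc(OC)c4)sc3n2)c1` gives 1100 nM in a functional assay on FM3A cells (Mus musculus) for inhibition, read by cell counting, with a stated time of 2 days (on this read-out lower numbers stand for stronger inhibition and higher numbers for weaker inhibition), the lowest of the three numbers recorded. Compound 2 `Nc1cccc(-c2cn3nc(CCc4ccccc4)sc3n2)c1` gives 29000 nM in this assay, and compound 3 `COc1ccc(Cc2nn3cc(-c4cccc(N)c4)nc3s2)cc1` gives 100000 nM. For the measured compounds named here, the one step between neighbouring measured compounds, a 3.4-fold higher number from compound 2 to compound 3 (0.54 log units; beyond the scatter), touches a different place on the shared core and says nothing about the present change. Compound 4 `C=C(Br)C(=O)Nc1cccc(-c2cn3nc(-c4cccc(OC)c4)sc3n2)c1` differs from compound 1 by 3-methoxyphenyl in place of 3-methoxybenzyl on an aromatic carbon. Going by the values given here, no measured pair tests the loss of the saturated chain carbon between the core and the methoxy-bearing ring, and the expected step of a 1.4-fold higher number from compound 1 to compound 4 (0.13 log units; within the scatter) is taken as none beyond the scatter, with wide uncertainty. Compound 4 is therefore estimated at 1500 nM, within 300 nM to 8000 nM.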

Compound 4, half-maximal inhibitory concentration: 500 nM
Compound 4: middle estimate off by 3.0-fold (0.48 log units), on the high side; measured number inside the range.
By their numbers in this assay, from the lowest: compound 4; then compound 1; then compound 2; then compound 3.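

In this assay, 3-methoxyphenyl in place of 3-methoxybenzyl on this aromatic carbon gives a 2.2-fold lower number from compound 1 to compound 4 (0.34 log units; beyond the scatter), a modest step. Within this pair, the saturated chain carbon is therefore not required for inhibition, and removing it lowers the number. Nothing measured here accounts for the difference.

From the compounds shown here alone, it remains open whether a hydroxyl group in place of the methoxy would keep this lower number. Going by these compounds, it is equally open how a longer chain, such as 3-methoxyphenethyl, would read at this carbon.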